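Hydroxymethyl removal across two cores: series notes

A few compounds are considered here, and "the series" means these few. Any claim that something is new, unique, unknown or untested is made for them only; others in the source may bear on it.

Measured so far:
compound 1, `N=c1oc2ccc(Br)cc2cc1C(=O)NCC(O)CO`, in an assay on HEK293 cells for displacement of a labelled ligand from adenosine receptor A2b (Homo sapiens), read by scintillation counting, with a stated time of 30 min, tested at 10 uM (a higher number here means more inhibition at the concentration tested (going by the name of the read-out), a lower number less inhibition), gives 4%
compound 2, `N=c1oc2ccc(Br)cc2cc1C(=O)NCCO`, gives 15%
compound 3, `COc1cccc2cc(C(=O)NCC(O)CO)c(=O)oc12`, gives 25%

Compound 1 and compound 2 share one core and differ only by hydrogen in place of hydroxymethyl on a saturated chain carbon bound to an oxygen on a saturated carbon and a saturated chain carbon. That change gave a number 11 percentage points higher from compound 1 to compound 2 (beyond the scatter). Compound 3 sits on a different core; how the two cores differ is not broken down here. Compound 3 gives the highest number of the three, but its gap to compound 2 lies within the scatter, so no order between those two is claimed; its gap to compound 1 lies beyond it.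

Compound 4, `COc1cccc2cc(C(=O)NCCO)c(=O)oc12`, has not been measured. It differs from compound 3 by hydrogen in place of hydroxymethyl on a saturated chain carbon bound to an oxygen on a saturated carbon and a saturated chain carbon, the same change as between compound 1 and compound 2, at a place described in the same words. Going by the values given here, the expectation for compound 4 in this assay is a step of a number 9 percentage points higher from compound 3 to compound 4 (within the scatter), comparable to the earlier one, because a number 11 percentage points higher from compound 1 to compound 2 (beyond the scatter) is the only measured instance of this change; whether it carries over to the core of compound 3 is untested. Compound 4 is therefore estimated at 34%, between 18% and 50%.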

Compound 4, a percentage reported as inhibition, at one concentration (the size of the read-out at that concentration, not a potency): 7%
Beside the measured number, compound 4's estimate is 27 percentage points above it; measured number outside the range, below it.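

On the core of compound 3, hydrogen in place of hydroxymethyl gives a number 18 percentage points lower from compound 3 to compound 4 (beyond the scatter), so the direction seen on the core of compound 1 does not carry over in this assay. Going by these compounds alone, the two steps differ in sign and the gap between them exceeds what repeat measurements would explain: the same change on two cores in this assay, a number 11 percentage points higher (beyond the scatter) from compound 1 to compound 2 and a number 18 percentage points lower (beyond the scatter) from compound 3 to compound 4, 29 percentage points apart, beyond the scatter of two such steps This shows that, for these two matched pairs, the result of the change depends on the core; it does not show which feature of the cores is responsible, and with only two cores and one concentration it gives no rule for a further core and no measure of potency.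

Still open, from the compounds shown here alone, is whether a longer chain, an amine or a carboxylic acid in place of 2-hydroxyethyl would follow the trend of the core of compound 1 or that of compound 3. Also open, going by these compounds, is which of the two opposite steps a further core carrying both 2,3-dihydroxypropyl and 2-hydroxyethyl would resemble.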